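The source may report more compounds than this note shows. Statements on the series, on what has been measured and on what is new or still open speak of the compounds shown alone.

Measured so far:
- compound 1 `CC[C@]1(C(=O)O)CC[C@H](C(=O)N2CC[C@](c3ccc(C(F)(C(F)(F)F)C(F)(F)F)cc3)(S(=O)(=O)c3ccc(F)cc3)C2)CC1` with 100%
- compound 2 `COC(=O)[C@H]1CC[C@H](C(=O)N2CC[C@](c3ccc(C(F)(C(F)(F)F)C(F)(F)F)cc3)(S(=O)(=O)c3ccc(F)cc3)C2)CC1` with "not determined" (no result reported)

Within the data shown here, in an ADME assay on microsomes from liver (Homo sapiens) for metabolic stability, with a stated time of 10 min (on this read-out higher numbers stand for a more stable compound and lower numbers for a less stable compound), compound 2 has no single number ("not determined" (no result reported)), so no measured step starts from it. The next structure is compound 3 `O=C(N1CC[C@](c2ccc(C(F)(C(F)(F)F)C(F)(F)F)cc2)(S(=O)(=O)c2ccc(F)cc2)C1)C1(CO)CCS(=O)(=O)CC1`. The change is 4-(hydroxymethyl)-1,1-dioxothian-4-yl in place of 4-(methoxycarbonyl)cyclohexyl on a carbonyl carbon, which puts 4-(hydroxymethyl)-1,1-dioxothian-4-yl in place of 4-(methoxycarbonyl)cyclohexyl on a carbonyl carbon. Among the measured compounds shown here, the only guide is compound 1 (100%), which shares the core, so no step beyond the scatter is expected in this assay, and the data fix no direction. For compound 3 the expected value is 85%, within an estimated range from 60% to 100%.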

Compound 3, percent of the compound remaining: 75%
For compound 3 the middle estimate is 10 percentage points above the measured one; low and high end bracket the measured number.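

In this assay, placing 4-(hydroxymethyl)-1,1-dioxothian-4-yl instead of 4-carboxy-4-ethylcyclohexyl on the carbonyl carbon gives a number 25 percentage points lower from compound 1 to compound 3 (beyond the scatter). Among these compounds, with the shared core unchanged, this shows that the group at this place can shift the read-out; no step from compound 2 can be read. Nothing measured here explains the shift.

The two groups differ in several features at once, so the compounds shown do not tell which feature carries the step. Going by these compounds, how an amine in place of the hydroxymethyl would read also stays open.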